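Thiophen-2-yl for furan-2-yl: no step expected

The source may report more compounds than this note shows. Statements on the series, on what has been measured and on what is new or still open speak of the compounds shown alone.

In an ADME assay on HepG2 2.2.15 cells (Homo sapiens) for cytotoxicity, read by MTT assay (a higher number here means that more compound is tolerated, a lower number that less compound is tolerated), compound 1 (`C=C1CC[C@@H]2[C@](C)(COC(=O)c3cccnc3)[C@H](O)CC[C@@]2(C)[C@@H]1C/C=C1\C=COC1=O`) gives 2050000 nM. Compound 2 (`C=C1CC[C@@H]2[C@](C)(COC(=O)c3ccco3)[C@H](O)CC[C@@]2(C)[C@@H]1C/C=C1\C=COC1=O`) gives > 2150000 nM, which is a limit of the assay and not a number. Compound 2 can therefore be placed only by that limit, and no exact value is available to start from.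

Compound 3 (`C=C1CC[C@@H]2[C@](C)(COC(=O)c3cccs3)[C@H](O)CC[C@@]2(C)[C@@H]1C/C=C1\C=COC1=O`) keeps the shared core and changes only the acyl ring: thiophen-2-yl in place of furan-2-yl on a carbonyl carbon. Within the data shown here, one measured step bears on this, made at the same place on a carbonyl carbon. It is an at least 1.0-fold higher number from compound 1 to compound 2 (0.02 log units; that floor lies within the scatter), with pyridin-3-yl giving way to furan-2-yl. From the compounds shown here alone, that exchange of one aromatic ring for another shows no change beyond the scatter, although its upper size stays open. On the strength of this single step, no shift beyond the scatter is expected in this assay when thiophen-2-yl enters. The expected change is an at least 1.0-fold lower number from compound 2 to compound 3 (0.01 log units; that floor lies within the scatter), and this estimate is uncertain since its starting point is a limit. The estimated value for compound 3 is 2100000 nM. The expected range for compound 3 runs from 1100000 nM to 3000000 nM.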

Compound 3, half-maximal cytotoxic concentration: 2470000 nM
Estimate against measurement, compound 3: 1.2-fold (0.07 log units) below; measured number inside the range.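

In this assay, the exchange of one aromatic ring for another at this place gives a 1.2-fold higher number from compound 1 to compound 3 (0.08 log units; within the scatter), a step at this position whose size can be read in full, which the earlier step, with its open upper size, did not offer. Compound 2 is held only by a limit, so its step to compound 3 cannot be read: the limit of > 2150000 nM in this assay, at which 1 of the 3 values shown sits. Compound 1 and compound 3 thus show that a six-membered pyridin-3-yl ring and a five-membered thiophen-2-yl ring at this place lie within the scatter of each other in this assay, with both exact values standing on the same footing.

From the compounds shown here alone, the exact value of compound 2 stays open, and with it whether furan-2-yl and thiophen-2-yl differ at all in this assay. All three compounds shown carry an aromatic ring on this carbonyl carbon, and it remains open whether the same picture would hold with an amine, a carboxylic acid or a longer alkyl chain in that place.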